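Swapping the Propargyloxy Arm for a 2-Chlorophenyl Group

A few compounds are considered here, and "the series" means these few. Any claim that something is new, unique, unknown or untested is made for them only; others in the source may bear on it.

Two compounds of the shared core have been examined in a functional assay on HEL cells (Homo sapiens) for inhibition; a lower number here means that less compound is tolerated, a higher number that more compound is tolerated. Compound 1, `O=C1c2ccccc2N(Cc2ccccc2Cl)S(=O)(=O)N1COCc1ccccc1`, gives in this assay > 50000 nM, which is a limit of the assay and not a number. Compound 2, `C#CCOCN1c2ccccc2C(=O)N(Cc2ccccc2)S1(=O)=O`, gives in this assay > 140000 nM, likewise a limit. Among the measured compounds shown here, compound 2 therefore stands only at a limit; with one value at the limit of > 140000 nM in this assay, at which 1 of the 2 values shown sits, and one at the limit of > 50000 nM in this assay, at which 1 of the 2 values shown sits, neither compound is placed relative to the other, and no step between measured compounds is available to size any change. The untested compound 3, `O=C1c2ccccc2N(Cc2ccccc2Cl)S(=O)(=O)N1Cc1ccccc1`, differs from compound 2 by 2-chlorophenyl in place of propargyloxy on a saturated chain carbon bound to a sulfonamide nitrogen in a ring. Compound 1 also carries a 2-chlorobenzyl group on the sulfonamide nitrogen and gives > 50000 nM, a limit. Compound 3 is consequently expected to stay beyond the range of measurable toxicity, with a step from compound 2 estimated as an at least 1.4-fold lower number from compound 2 to compound 3 (0.14 log units; that floor lies within the scatter), that is, none beyond the scatter. The estimate for compound 3 in this assay is 100000 nM, with a plausible range from 30000 nM to 300000 nM.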

Compound 3, half-maximal cytotoxic concentration: 88000 nM
The estimate for compound 3 lay 1.1-fold (0.06 log units) above the measured number; measured number inside the range.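

In this assay compound 3 gives 88000 nM, the first value among these compounds that is a number and not a limit, so a (propargyloxy)methyl to 2-chlorobenzyl change at this place yields a compound with a readable half-maximal cytotoxic concentration. Replacing propargyloxy with 2-chlorophenyl on a saturated chain carbon bound to a sulfonamide nitrogen in a ring gives an at least 1.5-fold lower number from compound 2 to compound 3 (0.20 log units; that floor lies within the scatter), so the change is bounded from one side only and may or may not exceed the usual scatter. The step from compound 1 to compound 3 cannot be read, because compound 1 stands at a limit: the limit of > 50000 nM in this assay, at which 1 of the 3 values shown sits.

The compounds shown leave open how much of the step belongs to the chlorine and how much to the phenyl ring, and how far compound 2 truly lies from compound 3. They also leave open how this assay would read with an amine or a carboxylic acid in place of propargyloxy on the same chain carbon.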